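Chain extension on the amide side chain: compounds 1 to 4

The compounds below may be only part of what the source reports. "The series", "measured", "known", "first", "only" and "open" are said of these compounds alone.

Compound 1 `CN(C)C(=O)c1cc2cnc(Nc3ccc(C(=O)NCCCCN=C=S)cc3)nc2n1C1CCCC1` and compound 2 `CN(C)C(=O)c1cc2cnc(Nc3ccc(C(=O)NCCCCCN=C=S)cc3)nc2n1C1CCCC1` share one core and differ only in the length of the chain carrying the amide. In a functional assay on A549 cells (Homo sapiens) for inhibition, read by CCK-8 assay, with a stated time of 72 h, tested at 10 uM (a lower number here means a weaker effect, a higher number a stronger effect of the compound at the concentration tested), compound 1 gives 102%, and compound 2 gives 100%. The change between them is a group of 4 heavy atoms (2 carbon, 1 nitrogen, 1 sulfur; no ring) in place of a group of 3 heavy atoms (1 carbon, 1 nitrogen, 1 sulfur; no ring), on a saturated chain carbon, four bonds along the chain from an amide-type nitrogen, and it leaves the read-out essentially where it was, the step being a number 2 percentage points lower from compound 1 to compound 2 (within the scatter).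

Compound 3 `CN(C)C(=O)c1cc2cnc(Nc3ccc(C(=O)NCCCCCCN=C=S)cc3F)nc2n1C1CCCC1` sits on a different core; the difference between the two cores is not broken down here. In this assay compound 3 gives 22.9%, the lowest of the three numbers, and its gap to both compound 1 and compound 2 lies beyond the scatter.

Compound 4 `CN(C)C(=O)c1cc2cnc(Nc3ccc(C(=O)NCCCCCCCN=C=S)cc3F)nc2n1C1CCCC1` has not been measured. It differs from compound 3 by a group of 4 heavy atoms (2 carbon, 1 nitrogen, 1 sulfur; no ring) in place of a group of 3 heavy atoms (1 carbon, 1 nitrogen, 1 sulfur; no ring), on a saturated chain carbon, six bonds along the chain from an amide-type nitrogen. This is the same kind of change as that from compound 1 to compound 2, though not the same: there the group sat four bonds along the chain from an amide-type nitrogen, here it sits six bonds along the chain from an amide-type nitrogen. Since compound 1 and compound 2 show a step of only a number 2 percentage points lower from compound 1 to compound 2 (within the scatter) in this assay, compound 4 is expected to stay close to compound 3, with an estimated step of a number 2.1 percentage points higher from compound 3 to compound 4 (within the scatter). Compound 4 is therefore estimated at 25% in this assay, with a likely range from 8% to 48%; the lack of any second example of this change on the core of compound 3 keeps the range wide.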

Compound 4, a percentage reported as inhibition, at one concentration (the size of the read-out at that concentration, not a potency): 12.7%
Compound 4: middle estimate off by 12.3 percentage points, on the high side; the range from low to high includes it.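

On the core of compound 3, the longer amide side chain gives a modest fall in this assay, with a step of a number 10.2 percentage points lower from compound 3 to compound 4 (beyond the scatter), set against a number 2 percentage points lower from compound 1 to compound 2 (within the scatter) on the core of compound 1. The two steps cannot be told apart, so nothing here shows that the change behaves differently on the two cores: the same change on two cores in this assay, a number 2 percentage points lower (within the scatter) from compound 1 to compound 2 and a number 10.2 percentage points lower (beyond the scatter) from compound 3 to compound 4, 8.2 percentage points apart, within the scatter of two such steps. This does not show that the change carries over unaltered: each core offers a single example, the change sits at a different place along the chain on each, and the steps start from very different values, compound 1 at 102% and compound 3 at 22.9%.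

The compounds shown leave open how much of the gap between the two pairs belongs to the core and how much to chain length, and a comparison with the chain held constant and only the core changed would separate the two. Also open, going by these compounds, are whether a still longer chain continues the fall on the core of compound 3, and whether an amine or a carboxylic acid at the chain end keeps any of the read-out.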